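Methoxy for methylsulfanyl on the chain of compound 3

This account rests on a few compounds, and the source may have more. Where it says the series, first, only, none or still open, it means among the compounds named here.

The series shares one core carrying a chain on the aromatic ring. Compound 1 `OC[C@H]1O[C@@H](n2cnc3c(COc4ccccc4)ncnc32)[C@H](O)[C@@H]1O` has a phenoxymethyl chain; in a functional assay on CCRF-CEM cells (Homo sapiens) for inhibition, with a stated time of 72 h (a higher number here means a weaker inhibitor, a lower number a stronger inhibitor), compound 1 is recorded as "not determined" (no result reported). Compound 2 `OC[C@H]1O[C@@H](n2cnc3c(CSCc4ccccc4)ncnc32)[C@H](O)[C@@H]1O` carries a benzylsulfanylmethyl chain, and in this assay compound 2 gives 9200 nM. Compound 3 `CSCc1ncnc2c1ncn2[C@@H]1O[C@H](CO)[C@@H](O)[C@H]1O` carries a (methylsulfanyl)methyl chain; in this assay compound 3 gives 15000 nM, the highest of the two numbers recorded, with compound 2 nearest. Among the compounds with values here, the only measured step, a 1.6-fold higher number from compound 2 to compound 3 (0.21 log units; within the scatter), lies within the scatter.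

Compound 4 `COCc1ncnc2c1ncn2[C@@H]1O[C@H](CO)[C@@H](O)[C@H]1O` is the next entry. The change from compound 3 is methoxy in place of methylsulfanyl on a saturated chain carbon bound to an aromatic carbon. No measured step exchanges sulfur for oxygen at this position: the oxygen analogue of compound 2, compound 1, has no number, so nothing shown bears directly on this exchange. Within the data shown here, the one step available, a 1.6-fold higher number from compound 2 to compound 3 (0.21 log units; within the scatter), shows that a change on this chain can leave the number within the scatter. On that basis the step is expected to be small, and compound 4 is estimated to come out near compound 3, with the expected step of a 1.3-fold higher number from compound 3 to compound 4 (0.12 log units; within the scatter) inside the scatter. The estimate for compound 4 in this assay is 20000 nM, with a range from 7000 nM to 60000 nM.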

Compound 4, half-maximal inhibitory concentration: 6000 nM
Compound 4: the middle estimate sits 3.3-fold (0.52 log units) above what was measured, and the stated range ends above it.
By their numbers in this assay, from the lowest: compounds 4, 2 and 3 (each within the scatter of the next, the first and the last beyond it).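

In this assay, within the data shown here, methoxy in place of methylsulfanyl on a saturated chain carbon bound to an aromatic carbon gives a 2.5-fold lower number from compound 3 to compound 4 (0.40 log units; beyond the scatter), the first step on this chain to pass beyond the scatter, so exchanging sulfur for oxygen at this position does register in the read-out, and in the direction opposite to the one expected. The size of the chain's end group does not separate compounds in the same way: methoxy in place of benzylsulfanyl gives a 1.5-fold lower number from compound 2 to compound 4 (0.19 log units; within the scatter), so compound 2 cannot be told apart from compound 4, just as it cannot be told apart from compound 3, and only compound 3 and compound 4 stand clearly apart. Nothing measured alongside these numbers accounts for the difference between methoxy and methylsulfanyl.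

The compounds shown leave open whether the step belongs to oxygen in the chain in general or to methoxy alone, which an ethoxy or a hydroxy group on the same carbon would test. They also leave open how an amine or a carboxylic acid at this place would read in this assay.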